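The compounds below may be only part of what the source reports. "The series", "measured", "known", "first", "only" and "open" are said of these compounds alone.

Compound 1 `COc1ccc(-n2nc(C(N)=O)nc2-c2cc(OC)c(OC)c(OC)c2)cc1`: 92%
Compound 2 `COc1ccc(NC(=O)c2nc(-c3cc(OC)c(OC)c(OC)c3)n(-c3ccc(OC)cc3)n2)cc1`: 86%
Compound 3 `COc1ccc(-n2nc(C(=O)Nc3ccc(C(F)(F)F)cc3)nc2-c2cc(OC)c(OC)c(OC)c2)cc1`: 83%

In a functional assay on the whole organism for inhibition, with Rattus norvegicus as the target, read by paw edema, with stated times of 30 min and 3 h, at a dose of 0.28 mmol/kg by the oral route (on this read-out lower numbers stand for less inhibition and higher numbers for more inhibition at the one dose given (going by the name of the read-out)), compound 1 gives the largest of the three numbers, yet both a number 6 percentage points lower from compound 1 to compound 2 (within the scatter) and a number 9 percentage points lower from compound 1 to compound 3 (within the scatter) stay within the scatter, so the three compounds stand level. Compound 4 `COc1ccc(-n2nc(C(=O)Nc3ccc(C(=O)O)cc3)nc2-c2cc(OC)c(OC)c(OC)c2)cc1` is not yet measured. It differs from compound 1 by 4-carboxyphenyl in place of hydrogen on an amide-type nitrogen. The two steps that bear on this change are those from compound 1 to compounds 2 and 3, where an aryl group likewise replaced hydrogen on the amide-type nitrogen, and neither moved the read-out beyond the scatter; a number 3 percentage points lower from compound 2 to compound 3 (within the scatter) also stayed within it. Compound 4 is therefore expected to show a number 7 percentage points lower from compound 1 to compound 4 (within the scatter), no step beyond the scatter. The estimate for compound 4 is 85%, between 70% and 95%.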

Compound 4, a percentage reported as inhibition, in the whole organism at one dose (the size of the read-out at that dose, not a potency): 95%
The estimate for compound 4 lay 10 percentage points below the measured number; low and high end bracket the measured number.
By their numbers in this assay, from the lowest: compounds 3, 2, 1 and 4 (each within the scatter of the next, the first and the last beyond it).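

In this assay, adding a carboxy-bearing aryl group on the amide-type nitrogen leaves the read-out level with the plain amide, as a number 3 percentage points higher from compound 1 to compound 4 (within the scatter) shows, and a number 9 percentage points higher from compound 2 to compound 4 (within the scatter) likewise stays level with the methoxy partner. For the compounds shown here, only a number 12 percentage points higher from compound 3 to compound 4 (beyond the scatter) clears the scatter, making carboxy in place of trifluoromethyl the first change here to separate two compounds, though modestly. Nothing measured here accounts for that step.

Going by these compounds, whether a methyl ester or an amine in place of the carboxy would hold the read-out remains open. So does the effect of a longer alkyl chain in place of the aryl group on the amide-type nitrogen.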